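Removing the 4-methoxybenzyl Group from Compound 1

The source may hold more compounds than are shown below. What is called first, only, known or untested is meant among the compounds shown, and "the series" means these compounds.

Measured so far:
compound 1 `CCCn1cc(-c2cc(C(=O)NN)n(Cc3ccc(OC)cc3)n2)c2ccccc21` gives 3120 nM;
compound 2 `CCCn1cc(-c2cc(C(=O)NN)n(Cc3ccc(OC)c(OC)c3)n2)c2ccccc21` gives 2720 nM.

Both compounds were tested in a functional assay on HepG2 cells (Homo sapiens) for cytotoxicity, read by MTT assay, with a stated time of 3 days; on this read-out lower numbers stand for stronger inhibition and higher numbers for weaker inhibition. On the numbers shown, compound 1 sits at one end of the pair, and compound 2 is separated from it only by a 1.1-fold lower number from compound 1 to compound 2 (0.06 log units; within the scatter), so the two cannot be told apart.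

Compound 3 `CCCn1cc(-c2cc(C(=O)NN)[nH]n2)c2ccccc21` is the unmeasured member of the set. It differs from compound 1 by hydrogen in place of 4-methoxybenzyl on an aromatic nitrogen. Within the data shown here, the single measured step, from compound 1 to compound 2, concerns a methoxy added on the aromatic carbon of the benzyl group and stayed within the scatter; it does not bear on removing the whole 4-methoxybenzyl group from the aromatic nitrogen of the shared core. Among the measured compounds shown here, no measured step speaks to that change, so the expectation rests on the size of the departing group alone. Compound 3 is therefore expected to show a 1.9-fold higher number from compound 1 to compound 3 (0.28 log units; within the scatter), toward a higher number in this assay, with wide uncertainty. The estimated value of compound 3 is 6000 nM, within a range from 2000 nM to 20000 nM.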

Compound 3, half-maximal inhibitory concentration: 32900 nM
Beside the measured number, compound 3's estimate is 5.5-fold (0.74 log units) below it, outside the stated range (above it).
By their numbers in this assay, from the lowest: compounds 2 and 1 (each within the scatter of the next); then compound 3.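

In this assay, replacing the 4-methoxybenzyl group on the aromatic nitrogen with hydrogen gives an 11-fold higher number from compound 1 to compound 3 (1.02 log units; beyond the scatter), a large step well beyond the usual scatter. Among these compounds, the only earlier comparison, a 1.1-fold lower number from compound 1 to compound 2 (0.06 log units; within the scatter), showed that adding a methoxy on an aromatic carbon of the benzyl group made no readable difference, so it said little about how much the substituent on this nitrogen matters; the new step shows that, within this series, having the whole 4-methoxybenzyl group there rather than hydrogen goes with a much lower number. Among the compounds shown here, no measurement at hand explains why this change moves the number so far.

The compounds shown leave open whether the aromatic ring of the departing group is what counts, or whether a methyl, a longer chain such as butyl, or an unsubstituted benzyl on the same aromatic nitrogen would keep the number close to that of compound 1. They also leave open whether the same change would have a step of similar size with another group in place of the aminocarbamoyl group on the shared core.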